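A few compounds are considered here, and "the series" means these few. Any claim that something is new, unique, unknown or untested is made for them only; others in the source may bear on it.

Compound 1, `COc1cc(/C=N/NC(=O)CCCc2nc3ccccc3c(=O)[nH]2)ccc1O`, compound 2, `COc1cc(/C=N/NC(=O)CCCc2nc3ccccc3c(=O)[nH]2)cc(OC)c1O`, and compound 3, `COc1cc(/C=N/NC(=O)CCc2nc3ccccc3c(=O)[nH]2)ccc1O`, were all examined in a physicochemical assay, read by spectrophotometry, with a stated time of 15 min; a higher number here means a weaker inhibitor, a lower number a stronger inhibitor. In this assay compound 1 gives 280000000 nM, compound 2 gives 225000000 nM and compound 3 gives 290000000 nM. From compound 1 to compound 2 the change is methoxy in place of hydrogen on an aromatic carbon, and the step it made was a 1.2-fold lower number from compound 1 to compound 2 (0.09 log units; within the scatter). Compound 4, `COc1cc(/C=N/NC(=O)CCc2nc3ccccc3c(=O)[nH]2)cc(OC)c1O`, carries the same change on the core of compound 3: methoxy in place of hydrogen on an aromatic carbon. The difference between the two cores is not broken down here; the values of compound 1 and compound 3 lie close together. Because a 1.2-fold lower number from compound 1 to compound 2 (0.09 log units; within the scatter) stayed within the scatter, a similar step, a 1.2-fold lower number from compound 3 to compound 4 (0.09 log units; within the scatter), is expected for compound 4. Compound 4 is thus estimated at 235000000 nM, most likely between 120000000 nM and 460000000 nM.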

Compound 4, half-maximal inhibitory concentration: 275000000 nM
Beside the measured number, compound 4's estimate is 1.2-fold (0.07 log units) below it; the measured number falls inside the stated range.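

In this assay, methoxy in place of hydrogen on an aromatic carbon gave a 1.1-fold lower number from compound 3 to compound 4 (0.02 log units; within the scatter), and on the other core it gave a 1.2-fold lower number from compound 1 to compound 2 (0.09 log units; within the scatter). Both steps lie within the scatter, so on these two cores the change shows no effect that can be told apart from repeat-measurement noise, but this does not show that it acts alike on both, as a small real effect could stay hidden in that noise. Nothing measured here offers an explanation for this result.

As far as these compounds go, it remains open whether an amine or a carboxylic acid on that aromatic carbon would give a step beyond the scatter. From the compounds shown here alone, whether the methoxy step would stay this small with a longer chain on the core is also open.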